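Two weak growth inhibitors and a shortened side chain

This account rests on a few compounds, and the source may have more. Where it says the series, first, only, none or still open, it means among the compounds named here.

Compound 1 `C[C@H]1CC(Cl)=C([Si](C)(C)C)[C@@H](C2CCCCC2)O1` and compound 2 `C[C@@H]1O[C@H](CCC=C(Br)Br)C([Si](C)(C)C)=C(Cl)[C@H]1C` share a core that carries a trimethylsilyl group and a chlorine on a ring double bond. In a functional assay on SW1573 cells (Homo sapiens) for antiproliferative activity (a lower number here means a stronger inhibitor of growth, a higher number a weaker inhibitor of growth), compound 1 gives 31000 nM. In this assay compound 2 gives 43000 nM; on the numbers available it stands at the top of the pair, but its gap to compound 1 lies within the usual scatter, so the two cannot be told apart. Both are weak inhibitors of growth.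

Compound 3 `C=CCC[C@H]1O[C@@H](C)[C@H](C)C(Cl)=C1[Si](C)(C)C` has not yet been measured. It differs from compound 2 in one place: vinyl in place of 2,2-dibromoethenyl on a saturated chain carbon, two bonds along the chain from a saturated ring carbon. Going by the values given here, no measured pair shows what such a change does here, and the only two numbers at hand are close to each other, so there is no basis for expecting a large shift in either direction. The step from compound 2 to compound 3 is therefore estimated to stay within the scatter, at a 1.2-fold higher number from compound 2 to compound 3 (0.07 log units; within the scatter). For compound 3 in this assay the expected value is 50000 nM, with a range from 20000 nM to 120000 nM.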

Compound 3, concentration for total growth inhibition: 55000 nM
The estimate for compound 3 lay 1.1-fold (0.04 log units) below the measured number, and the stated range covers the measured number.
By their numbers in this assay, from the lowest: compounds 1, 2 and 3 (each within the scatter of the next).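

In this assay, going by these compounds alone, the exchange of 2,2-dibromoethenyl for vinyl on a saturated chain carbon, two bonds along the chain from a saturated ring carbon, gives a 1.3-fold higher number from compound 2 to compound 3 (0.11 log units; within the scatter); this is the first comparison here of two compounds that differ in one place. It shows that both bromine atoms can be removed from the end of this chain, leaving a plain vinyl group, without a difference that can be told from the scatter, so in this pair the dibromo end is not needed to keep the measured level of growth inhibition. Nothing available bears on why the two compounds cannot be told apart.

The compounds shown leave open whether a group of another kind at this place, such as an amine, a carboxylic acid or a hydroxyl group, would move the number beyond the scatter in either direction. Within the data shown here, they also leave open whether a longer chain ending in the same vinyl group would do so, and compound 1 differs from the other two in more than one place, so it gives no further step to read.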